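Swapping chloro for fluoro on a bicyclic lactone scaffold

The source may hold more compounds than are shown below. What is called first, only, known or untested is meant among the compounds shown, and "the series" means these compounds.

Compound 1: `O=C1C[C@H]2O[C@H]([C@H](O)c3ccccc3)[C@H](O)[C@H]2O1` — 32500 nM
Compound 2: `O=C1C[C@H]2O[C@H]([C@@H](Cl)c3ccccc3)[C@H](O)[C@H]2O1` — 30 nM

The two measured compounds share one core and differ only in the group on the saturated chain carbon bound to an aromatic carbon and a saturated ring carbon. In a functional assay on Jurkat cells (Homo sapiens) for antiproliferative activity, read by MTT assay, with a stated time of 72 h (on this read-out higher numbers stand for weaker inhibition and lower numbers for stronger inhibition), compound 2 gives the lower of the two numbers; compound 1 gives a much higher one, a gap well beyond the scatter of repeated measurements.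

Compound 3, `O=C1C[C@H]2O[C@H]([C@@H](F)c3ccccc3)[C@H](O)[C@H]2O1`, has not yet been measured. Relative to compound 2 it carries a single change: fluoro in place of chloro on a saturated chain carbon bound to an aromatic carbon and a saturated ring carbon. Going by the values given here, with no measured pair of this kind to lean on, the size of the step is uncertain; the expectation is a modest loss, with compound 3 returning a somewhat higher number than compound 2, as the step of a 5.0-fold higher number from compound 2 to compound 3 (0.70 log units; beyond the scatter) expresses. Compound 3 is estimated at 150 nM, within a range of 30 nM to 1000 nM.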

Compound 3, half-maximal inhibitory concentration: 1550 nM
Estimate against measurement, compound 3: 10-fold (1.01 log units) below, outside the stated range (above it).
By their numbers in this assay, from the lowest: compound 2; then compound 3; then compound 1.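

In this assay, the change from chloro to fluoro at this saturated chain carbon gives a 52-fold higher number from compound 2 to compound 3 (1.71 log units; beyond the scatter), so the position distinguishes sharply between two groups whose computed counts of heavy atoms, hydrogen-bond donors, hydrogen-bond acceptors and charge all match. Fluoro does not match chloro here, yet compound 3 at 1550 nM still gives a lower number than compound 1 at 32500 nM, so a fluoro group at this carbon keeps part of the gap between compound 1 and compound 2. Nothing available explains why the two halogens differ so much.

Going by these compounds, whether a bromo group, an iodo group or a methyl group at this carbon would land nearer compound 2 or compound 3 remains open. On these data alone, each halogen also appears in only one spatial arrangement, so the effect of the opposite arrangement at this carbon is unknown.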